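Working notes on growth inhibition: from compound 3 to compound 4

The compounds below may be only part of what the source reports. "The series", "measured", "known", "first", "only" and "open" are said of these compounds alone.

Measured so far:
compound 1 `N#C/C(=C\N1CCN(C(=O)c2ccco2)C1=S)C(N)=O`: 12000 nM
compound 2 `N#C/C(=C\N1CCN(C(=O)c2ccco2)C1=S)C(=O)c1ccccc1`: 8600 nM
compound 3 `O=CN1CCN(c2ccc(Cl)cc2)C1=S`: 14700 nM

All three numbers come from a functional assay on SN12C cells (Homo sapiens) for inhibition, read by sulforhodamine B assay, with a stated time of 48 h; on this read-out lower numbers stand for stronger inhibition of growth and higher numbers for weaker inhibition of growth. Compound 3 is numerically the largest of the three, a distinction the scatter does not support: its gap to compound 1 and its gap to compound 2 both lie within the scatter, so the three compounds cannot be ordered on these numbers.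

The next compound, compound 4 `O=CN1CCN(c2ccc(Cl)c(Cl)c2)C1=S`, differs from compound 3 in one place: chloro in place of hydrogen on an aromatic carbon. Within the data shown here, the only measured step, a 1.4-fold lower number from compound 1 to compound 2 (0.14 log units; within the scatter), concerns a carbonyl substituent on a different core and does not bear on a second chloro group on this ring. Among the measured compounds shown here, no measured pair shows what an added ring chloro does in this assay.

With nothing to point either way, the step from compound 3 to compound 4 is expected to be a 1.2-fold lower number from compound 3 to compound 4 (0.09 log units; within the scatter), no change beyond the scatter. Compound 4 is therefore estimated at 12000 nM, with a range from 5000 nM to 30000 nM.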

Compound 4, concentration for 50% growth inhibition: 13600 nM
For compound 4 the middle estimate is 1.1-fold (0.05 log units) below the measured one, and the stated range covers the measured number.
By their numbers in this assay, from the lowest: compounds 2, 1, 4 and 3 (each within the scatter of the next).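

In this assay, chloro in place of hydrogen on an aromatic carbon, ortho to a chloro group and meta to a group of 8 heavy atoms, gives a 1.1-fold lower number from compound 3 to compound 4 (0.03 log units; within the scatter) and so stays within the scatter. Among these compounds, this is the first measured pair to test an added ring chloro, and at this position the change brings no shift in growth inhibition beyond the scatter. Nothing at hand gives a reason for this outcome or a measured property of the added group.

On these data alone, whether an amine, a methoxy group or a carboxylic acid at this same position would shift the number beyond the scatter remains open. Also open, as far as these compounds go, is whether a longer chain in place of the hydrogen on the carbonyl carbon shared by compound 3 and compound 4 would do so.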